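The compounds below may be only part of what the source reports. "The series", "measured", "known", "first", "only" and "open" are said of these compounds alone.

Measured compounds:
- compound 1 `CC(C)[C@@H](c1ccc(-c2ccc3cccc(F)c3c2)[nH]c1=O)[C@@H]1OC(=O)NC1=O`: 85 nM
- compound 2 `CC(C)C(c1ccc(-c2ccc3cccc(F)c3c2)[nH]c1=O)C1NC(=O)NC1=O`: 50 nM
- compound 3 `CC(C)/C(=C1\C(=O)NC(=O)N1C)c1ccc(-c2ccc3cccc(F)c3c2)[nH]c1=O`: 85 nM

All three were tested in an assay on membranes from Chem-1 cells for displacement of a labelled ligand from prostaglandin E2 receptor EP3 subtype (Homo sapiens), read by scintillation counting, with a stated time of 2 h; on this read-out lower numbers stand for stronger inhibition and higher numbers for weaker inhibition. Compound 2 gives 50 nM in this assay, compound 1 gives 85 nM and compound 3 gives 85 nM. The three numbers sit close together: compound 2 lies at the low end, but its separation from compound 1 and from compound 3 is each within the usual scatter, so the three compounds cannot be told apart on these numbers.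

Compound 4 `CC(C)C(CC1NC(=O)NC1=O)c1ccc(-c2ccc3cccc(F)c3c2)[nH]c1=O` has not yet been measured in this assay. Relative to compound 2, the change is (2,5-dioxoimidazolidin-4-yl)methyl in place of 2,5-dioxoimidazolidin-4-yl on a saturated chain carbon bound to an aromatic carbon and a saturated chain carbon. Within the data shown here, no measured pair among compounds 1, 2 and 3 shows a step of this kind, so the expected size rests on the structural change alone.

An estimate in this assay for compound 4 is 100 nM, with a range from 30 nM to 320 nM. The step that this estimate means, a 2.0-fold higher number from compound 2 to compound 4 (0.30 log units; within the scatter), is expected to be small, toward a weaker number but not clearly beyond the scatter.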

Compound 4, inhibition constant: 10 nM
Beside the measured number, compound 4's estimate is 10-fold (1.00 log units) above it; the measured number lies below the stated range.
By their numbers in this assay, from the lowest: compound 4; then compounds 2, 1 and 3 (each within the scatter of the next).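

In this assay, this saturated chain carbon bound to an aromatic carbon and a saturated chain carbon proves sensitive to how the ring is attached: (2,5-dioxoimidazolidin-4-yl)methyl in place of 2,5-dioxoimidazolidin-4-yl gives a 5.0-fold lower number from compound 2 to compound 4 (0.70 log units; beyond the scatter). Among these compounds, the earlier compounds offered no step between compounds differing in one place, so this is the first readable effect of a change at this position, and it favours the methyl-linked ring. Nothing available here accounts for the size or direction of this step.

The compounds shown leave open whether a longer chain, such as (2,5-dioxoimidazolidin-4-yl)ethyl, would extend this trend or reverse it. They also leave open whether the 2,5-dioxoimidazolidin-4-yl ring itself is needed on this link, a question that a carboxylic acid in its place could address.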